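This account rests on a few compounds, and the source may have more. Where it says the series, first, only, none or still open, it means among the compounds named here.

Measured compounds:
Compound 1 `CNC(=O)c1cc(C(=O)NC2CC2)cn(Cc2ccc(OC)cc2)c1=O` gives >= 143 ug/mL.
Compound 2 `CNC(=O)c1cccn(Cc2ccccc2)c1=O` gives 78 ug/mL.
Compound 3 `CNC(=O)c1cc(C(=O)NC2CC2)cn(Cc2cccc3[nH]c(C)nc23)c1=O` gives >= 198 ug/mL.

These three were measured in a physicochemical assay for solubility; a higher number here means a more soluble compound, a lower number a less soluble compound. For compound 1 the reading of >= 143 ug/mL is a limit of the assay and not a number. For compound 3 the reading of >= 198 ug/mL is likewise a limit and not a number. Within the data shown here, only compound 2 gives a plain number, 78 ug/mL, and it carries neither of the two amide substituents that compounds 1 and 3 share; no step between measured compounds is tracked here, so the comparison between compound 2 and the others shows only its two values. Compound 1 thus stands at the limit of >= 143 ug/mL in this assay, at which 1 of the 3 values shown sits, with compound 3 at the limit of >= 198 ug/mL in this assay, at which 1 of the 3 values shown sits, alongside it.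

The unmeasured compound 4 `CNC(=O)c1cc(C(=O)NC2CC2)cn(Cc2ccc3nc[nH]c3c2)c1=O` differs from compound 1 in one place: 1H-benzimidazol-6-yl in place of 4-methoxyphenyl on a saturated chain carbon bound to an aromatic nitrogen. Among the measured compounds shown here, with no measured step to lean on, the expectation rests on compound 3, whose limit of >= 198 ug/mL also comes with an aromatic bicycle carrying a hydrogen-bond donor on the saturated chain carbon bound to the aromatic nitrogen. Compound 4 is therefore expected to sit no further from compound 1 than the scatter of this assay, with an expected step that the limit leaves unreadable from compound 1 to compound 4. Compound 4 is estimated at 180 ug/mL, between 80 ug/mL and 320 ug/mL, most likely reported again only as a limit.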

Compound 4, solubility: >= 163 ug/mL
Compound 4 ended at the assay's limit (the forecaster's own chance of this, stated with the estimate: 60%); the middle value does not contradict the limit.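

Compound 1 and compound 4 both read as limits in this assay and not as numbers, so the step between them cannot be read. The compounds shown leave open where compound 1, compound 3 and compound 4 truly lie, and whether 1H-benzimidazol-6-yl in place of 4-methoxyphenyl changes the read-out at all.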